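A few compounds are considered here, and "the series" means these few. Any claim that something is new, unique, unknown or untested is made for them only; others in the source may bear on it.

Working notes on the series

Two compounds have so far been run in an assay on membranes from HeLa cells for displacement of a labelled ligand from adenosine receptor A3 (Homo sapiens), read by scintillation counting, with a stated time of 180 min, tested at 1 uM; a lower number here means less inhibition, a higher number more inhibition at the concentration tested (going by the name of the read-out). Compound 1 `CC1=C(C(=O)OC(C)(C)C)C(c2cccs2)NC(=O)N1` gives 7% in this assay. Compound 2 `CCC(CC)OC(=O)C1=C(C)NC(=O)NC1c1ccco1` gives 1% in this assay. Compound 2 thus holds the lowest of the two numbers, but the gap to compound 1 lies within the scatter, so the two compounds are not separated by this measurement; both sit at the low end of the read-out at the concentration tested.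

Compound 3 `CCC(CC)OC(=O)C1=C(C)NC(=O)NC1c1cccs1` has not yet been measured. It differs from compound 2 in one place: thiophen-2-yl in place of furan-2-yl on a saturated ring carbon. Among the measured compounds shown here, no pair of measured compounds differs by this change alone, so no measured step is available for it. For the measured compounds named here, the only guide is that compound 1, which also carries a thiophen-2-yl group, gives 7% in this assay, a number close to that of compound 2.

The step from compound 2 to compound 3 is expected to be a number 4 percentage points higher from compound 2 to compound 3 (within the scatter), that is, nothing beyond the scatter in either direction. Compound 3 is expected to give about 5% in this assay, with a range from -6% to 16%.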

Compound 3, a percentage reported as inhibition, at one concentration (the size of the read-out at that concentration, not a potency): 1%
Compound 3: middle estimate off by 4 percentage points, on the high side; low and high end bracket the measured number.
By their numbers in this assay, from the lowest: compounds 2, 3 and 1 (each within the scatter of the next).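

The swap on the saturated ring carbon now has a measured step in this assay: with pentan-3-yl on the oxygen, thiophen-2-yl in place of furan-2-yl gives no change at the digits printed from compound 2 to compound 3 (within the scatter), so this exchange of one five-membered aromatic ring for the other does not separate the two compounds. Among the compounds shown here, with thiophen-2-yl held in place, pentan-3-yl in place of tert-butyl on the oxygen next to the carbonyl group gives a number 6 percentage points lower from compound 1 to compound 3 (within the scatter), so this second change, which the earlier compounds could not isolate, also stays inside the scatter. All three compounds remain at the low end of the read-out at the concentration tested, and no further data on hand bear on this result.

The compounds shown leave open whether any group at either place can lift the read-out beyond the scatter, as only two five-membered aromatic rings and two branched groups appear there. A phenyl ring on the saturated ring carbon, or a longer chain such as hexyl on the oxygen, lies outside what these compounds cover, so neither place can yet be called insensitive to change.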